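A few compounds are considered here, and "the series" means these few. Any claim that something is new, unique, unknown or untested is made for them only; others in the source may bear on it.

Of the compounds shown here, two have so far been measured in an assay on isolated protein for inhibition of endoplasmic reticulum aminopeptidase 1 (Homo sapiens), with stated times of 15 min and 20 min; a higher number here means a weaker inhibitor, a lower number a stronger inhibitor. Compound 1 `CC(C)(NC(=O)c1cccc2cc(-c3ccc(Cl)cc3)oc12)C(=O)O` carries a carboxylic acid and gives 1030 nM. Compound 2 `CC(C)(NC(=O)c1cc(F)cc2cc(-c3ccc(Cl)cc3)oc12)C(N)=O` carries a carbamoyl group instead and has a fluorine on the shared core. In this assay compound 2 reached only > 10000 nM, which is a limit of the assay rather than a number (the limit of > 10000 nM in this assay, at which 1 of the 2 values shown sits). Compound 3 `O=C(NC1(C(=O)O)CC1)c1cc(F)cc2cc(-c3ccc(Cl)cc3)oc12` has not yet been measured in this assay. It differs from compound 2 in one place: 1-carboxycyclopropyl in place of 1-carbamoyl-1-methylethyl on an amide-type nitrogen. This change brings back a carboxylic acid of the kind found in compound 1, which matters because compound 1 gives 1030 nM in this assay. The step from compound 2 to compound 3 is therefore expected to be large, towards a stronger inhibitor, and is estimated as an at least 6.6-fold lower number from compound 2 to compound 3 (0.82 log units; beyond the scatter). Compound 3 is expected to give about 1500 nM, within a range from 400 nM to 6000 nM.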

Compound 3, half-maximal inhibitory concentration: 1120 nM
For compound 3 the middle estimate is 1.3-fold (0.13 log units) above the measured one; the range from low to high includes it.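

In this assay, placing 1-carboxycyclopropyl instead of 1-carbamoyl-1-methylethyl on the amide-type nitrogen gives an at least 8.9-fold lower number from compound 2 to compound 3 (0.95 log units; beyond the scatter). This size is only a minimum, since the value of compound 2 is a limit and not a number: the limit of > 10000 nM in this assay, at which 1 of the 3 values shown sits. Compound 1 and compound 2 differed in two places, whereas compound 3 keeps the fluorine of compound 2 and still gives a measured number, so the fluorine alone does not hold a compound at that limit.

The change swaps the carbamoyl group for a carboxylic acid and the two methyl groups for a cyclopropane ring at once, so the shared core bearing 1-carboxy-1-methylethyl would be needed to separate the two. From the compounds shown here alone, whether a tetrazole or a hydroxamic acid could take the place of the carboxylic acid also remains open.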